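Notes on the group at the ring amine

This account rests on a few compounds, and the source may have more. Where it says the series, first, only, none or still open, it means among the compounds named here.

The compounds share one core and differ only in the group carried on the saturated chain carbon bound to the amine nitrogen in the ring. Compound 1 `Cc1cc(C(=O)O)ccc1C(C)N1CCC[C@H](O[C@H](CO)c2cc(Cl)cc(Cl)c2)[C@@H]1c1ccccc1` has no result reported in an assay on isolated protein for activation of cGMP-dependent protein kinase 1 (Homo sapiens), read by ADP-Glo, with stated times of 30 min and 2 h (a lower number here means that less compound is needed, a higher number that more compound is needed for the effect), "nd" (no result reported). Compound 2 `O=C(O)c1ccc2nc(CN3CCC[C@H](O[C@H](CO)c4cc(Cl)cc(Cl)c4)[C@@H]3c3ccccc3)[nH]c2c1` gives 43000 nM in this assay. Compound 3 `OC[C@@H](O[C@H]1CCCN(Cc2ncc[nH]2)[C@H]1c1ccccc1)c1cc(Cl)cc(Cl)c1` reaches only the limit of the assay, > 200000 nM, so its position is known as a bound and not as a number. The step of an at least 4.6-fold higher number from compound 2 to compound 3 (0.66 log units; beyond the scatter) is therefore itself a bound. This is the one entry sitting at the limit of > 200000 nM in this assay, at which 1 of the 3 values shown sits.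

Compound 4 `O=C(O)c1ccc(CN2CCC[C@H](O[C@H](CO)c3cc(Cl)cc(Cl)c3)[C@@H]2c2ccccc2)c([N+](=O)[O-])c1` differs from compound 3 by 4-carboxy-2-nitrophenyl in place of 1H-imidazol-2-yl on a saturated chain carbon bound to an amine nitrogen in a ring. Among the measured compounds shown here, only the step from compound 2 to compound 3 bears on this change: it exchanged a larger aromatic group bearing a carboxylic acid for the small imidazole and raised the number beyond the scatter. Compound 4 brings back an aromatic ring with a carboxylic acid, here together with a nitro group, so a drop in the number beyond the scatter is expected, with the step estimated as an at least 4.0-fold lower number from compound 3 to compound 4 (0.60 log units; beyond the scatter). Compound 4 is thus expected to give about 50000 nM in this assay, within 15000 nM to 200000 nM, though a repeat of the limit cannot be excluded.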

Compound 4, half-maximal effective concentration in the cGMP-dependent protein kinase 1 assay: 13000 nM
Beside the measured number, compound 4's estimate is 3.8-fold (0.59 log units) above it; the whole stated range lies above it.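

In the cGMP-dependent protein kinase 1 assay the exchange of 1H-imidazol-2-yl for 4-carboxy-2-nitrophenyl gives an at least 15-fold lower number from compound 3 to compound 4 (1.18 log units; beyond the scatter), and this step is only a bound, as the value of compound 3 is a limit of the assay and not a number: the limit of > 200000 nM in the cGMP-dependent protein kinase 1 assay, at which 1 of the 4 values shown sits. The two groups bearing a carboxylic acid can also be compared directly, and the cGMP-dependent protein kinase 1 assay gives a 3.3-fold lower number from compound 2 to compound 4 (0.52 log units; beyond the scatter), so the five-membered aromatic ring of compound 2 is not required at this position for a measurable result, and a single six-membered aromatic ring of carbon only serves at least as well. In a physicochemical assay for solubility, at pH 7 (on this read-out higher numbers stand for higher solubility and lower numbers for lower solubility), compound 3 gives 120000 nM and compound 4 gives 110000 nM, two values within the scatter of each other, so the large step in the cGMP-dependent protein kinase 1 assay has no counterpart beyond the scatter on this read-out.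

The carboxylic acid and the nitro group enter together in compound 4, so the compounds shown do not assign the step to either one. A plain 4-carboxyphenyl group, or a primary amide in place of the carboxylic acid, would separate the two contributions.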